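A Benzyl Group in Place of 4-Methoxyphenyl

A few compounds are considered here, and "the series" means these few. Any claim that something is new, unique, unknown or untested is made for them only; others in the source may bear on it.

compound 1, `COc1ccc(N2CCN(C(=S)SCc3ccc(C(=O)Nc4ccccc4N)cc3)CC2)cc1`, 39.4%
compound 2, `Nc1ccccc1NC(=O)c1ccc(CSC(=S)N2CCc3cc(Cl)ccc32)cc1`, 40.1%

In a functional assay on HeLa cells (Homo sapiens) for antiproliferative activity, read by CCK-8 assay, with a stated time of 72 h, tested at 2 uM (on this read-out higher numbers stand for a stronger effect at the one concentration tested and lower numbers for a weaker effect), compound 1 gives 39.4%, and compound 2 sits within the scatter of that number, so nothing separates the two. Compound 3, `Nc1ccccc1NC(=O)c1ccc(CSC(=S)N2CCN(Cc3ccccc3)CC2)cc1`, has not been measured; it differs from compound 1 by benzyl in place of 4-methoxyphenyl on an amine nitrogen in a ring. For the measured compounds named here, no measured pair shows this change, so the step of a number 0.6 percentage points higher from compound 1 to compound 3 (within the scatter) is expected to be none beyond the scatter. Compound 3 is therefore expected to give 40%, with a range from 25% to 55%.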

Compound 3, a percentage reported as inhibition, at one concentration (the size of the read-out at that concentration, not a potency): 20.6%
Compound 3: middle estimate off by 19.4 percentage points, on the high side, outside the stated range (below it).
By their numbers in this assay, from the lowest: compound 3; then compounds 1 and 2 (each within the scatter of the next).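

For the compounds shown here, the swap of benzyl in place of 4-methoxyphenyl on this amine nitrogen gives the first readable step at this position: in this assay there is a number 18.8 percentage points lower from compound 1 to compound 3 (beyond the scatter). The position therefore does respond to the group it carries, and 4-methoxyphenyl goes with the higher number of this pair. Nothing at hand explains the step.

The change removes the methoxy and also swaps an aryl group for a benzyl group, so the compounds shown cannot separate the two. A phenyl or a 4-methoxybenzyl group on that nitrogen would bear directly on this question.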